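Pyridyl ether amides: bromo in place of ethyl

The compounds below may be only part of what the source reports. "The series", "measured", "known", "first", "only" and "open" are said of these compounds alone.

Two compounds of this series have numbers in a functional assay on CHO-K1 cells for antagonist activity at Orexin receptor type 2 (Homo sapiens), read by FLIPR and calcium flux; on this read-out lower numbers stand for stronger inhibition and higher numbers for weaker inhibition. Compound 1 `CCOC(=O)c1ccccc1C(=O)N1C[C@H](Oc2cc(C#N)ccn2)CC[C@H]1C` gives 21 nM in this assay. Compound 2 `CCc1ccnc(O[C@@H]2CC[C@@H](C)N(C(=O)c3ccccc3-n3nccn3)C2)c1` gives 11 nM in this assay. Compound 2 holds the lower of the two numbers, but its gap to compound 1 lies within the scatter, so the two cannot be ranked against each other on these data.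

Compound 3 `C[C@@H]1CC[C@@H](Oc2cc(Br)ccn2)CN1C(=O)c1ccccc1-n1nccn1` is not yet measured. It differs from compound 2 in one place: bromo in place of ethyl on an aromatic carbon. Going by the values given here, no measured pair shows this change, so its size is not known from the data. A single halogen replacing a two-carbon chain on the aromatic ring is a small alteration, and the two measured compounds already sit within the scatter of each other, which gives no hint of a strong dependence on this part of the molecule. The expected step is a 1.4-fold higher number from compound 2 to compound 3 (0.13 log units; within the scatter), meaning none beyond the scatter in either direction. Compound 3 is therefore estimated at 15 nM in this assay, with a range from 5 nM to 45 nM.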

Compound 3, half-maximal inhibitory concentration: 10 nM
For compound 3 the middle estimate is 1.5-fold (0.18 log units) above the measured one; the measured number falls inside the stated range.
By their numbers in this assay, from the lowest: compounds 3, 2 and 1 (each within the scatter of the next, the first and the last beyond it).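

In this assay, going by these compounds alone, the replacement of ethyl by bromo on the aromatic carbon opposite the ring nitrogen gives a 1.1-fold lower number from compound 2 to compound 3 (0.04 log units; within the scatter), the first direct reading of this change. With the amide part held fixed, 4-ethylpyridin-2-yl and 4-bromopyridin-2-yl therefore cannot be told apart on this read-out, so in this pair the position tolerates an exchange of ethyl for a single bromine without a step beyond the scatter. No measurement shown here bears on why the two groups read alike.

As far as these compounds go, two groups at one position give no trend, and whether an amine, a methoxy group or a longer chain such as butyl at this place would stay within the scatter of compound 2 remains open. Compound 1 differs from compound 2 and from compound 3 in more than one place, so the nitrile on its aromatic ring cannot be read separately from its ethyl ester side of the amide, and a nitrile on the amide part of compound 3 would be needed for that comparison.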